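The source may hold more compounds than are shown below. What is called first, only, known or untested is meant among the compounds shown, and "the series" means these compounds.

Measured in a functional assay on KG-1 cells (Homo sapiens) for antiproliferative activity, read by CCK-8 assay, with a stated time of 72 h; on this read-out higher numbers stand for weaker inhibition and lower numbers for stronger inhibition:
- Compound 1 `Cc1ccc(C(=O)Nc2cccc(C(F)(F)F)c2)cc1-c1ccc2c(-c3cn[nH]c3)n[nH]c2c1`: > 1000 nM, a limit of the assay and not a number
- Compound 2 `Cc1ccc(C(=O)Nc2cccc(C(F)(F)F)c2)cc1-c1ccc2c(-c3cnn(C)c3)n[nH]c2c1`: 65.7 nM
- Compound 3 `Cc1ccc(C(=O)Nc2cccc(C(F)(F)F)c2)cc1-c1ccc2c(-c3cnn(C(C)C)c3)n[nH]c2c1`: 452 nM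

Of the two true numbers, compound 3 holds the higher, so it is the weaker inhibitor of that pair. Compound 4 `Cc1ccc(C(=O)Nc2cccc(C(F)(F)F)c2)cc1-c1ccc2c(-c3cnn(C4CCOC4)c3)n[nH]c2c1` differs from it by oxolan-3-yl in place of isopropyl on an aromatic nitrogen, with oxolan-3-yl in place of isopropyl on an aromatic nitrogen. Two earlier changes at this nitrogen bear on the step. The first was large, an at least 15-fold lower number from compound 1 to compound 2 (1.18 log units; beyond the scatter). The second was modest and ran the opposite way, a 6.9-fold higher number from compound 2 to compound 3 (0.84 log units; beyond the scatter). With no steady trend in group size, and compound 1 going against any rule that larger is worse, no step beyond the scatter is expected in this assay. The expected change is a 1.1-fold lower number from compound 3 to compound 4 (0.05 log units; within the scatter). For compound 4 the estimate is 400 nM, with an expected range of 110 nM to 1400 nM.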

Compound 4, half-maximal inhibitory concentration: 304 nM
The estimate for compound 4 lay 1.3-fold (0.12 log units) above the measured number, within the range that was stated.
By their numbers in this assay, from the lowest: compound 2; then compounds 4 and 3 (each within the scatter of the next). At a limit, above all of these: compound 1.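

In this assay, replacing isopropyl with oxolan-3-yl, which brings a ring and a hydrogen-bond acceptor, moves the number only within the scatter: a 1.5-fold lower number from compound 3 to compound 4 (0.17 log units; within the scatter). The methyl group keeps its lead over this ring, a 4.6-fold higher number from compound 2 to compound 4 (0.67 log units; beyond the scatter), while the ring still stands clear of plain hydrogen, an at least 3.2-fold lower number from compound 1 to compound 4 (0.51 log units; beyond the scatter). That last comparison rests on compound 1, whose value is a limit and not a number: the limit of > 1000 nM in this assay, at which 1 of the 4 values shown sits.

From the compounds shown here alone, whether an ethyl group or a chain ending in an amine on this nitrogen would come closer to methyl stays open. The ring's contribution also remains unseparated from that of its oxygen, a question a cyclopentyl group could address.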